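The compounds below may be only part of what the source reports. "The series", "measured", "known", "first", "only" and "open" are said of these compounds alone.

Compound 1 `CSc1nc2ccccc2n1C1CCN(CCCC(=O)c2ccc(F)cc2)CC1` bears a methylsulfanyl group on its core and a chain ending in a fluorophenyl ketone; in a functional assay on the whole organism (strain STD-ddY) with Mus musculus as the target, with stated times of 1 h and 24 h (on this read-out lower numbers stand for an effect already at smaller amounts and higher numbers for an effect only at larger amounts of compound), compound 1 gives 0.68 mg/kg. Compound 2 `O=C(CCCN1CCC(n2c(SCCO)nc3ccccc32)CC1)c1ccc(F)cc1` differs from it by hydroxymethyl in place of hydrogen on a saturated chain carbon bound to a sulfur. In this assay compound 2 gives no number, only the limit > 3 mg/kg. That single change is recorded as an at least 4.4-fold higher number from compound 1 to compound 2 (0.64 log units; beyond the scatter), a step that reaches (the limit of > 3 mg/kg in this assay, at which 1 of the 3 values shown sits). Compound 3 `CSc1nc2ccccc2n1C1CCN(CCCC(c2ccc(F)cc2)c2ccc(F)cc2)CC1` keeps the methylsulfanyl group but has a different core; how its core differs from that of compound 1 is not broken down here. In this assay compound 3 gives 2.4 mg/kg, the highest number among the measured compounds and a larger figure than compound 1. Compound 4 `OCCSc1nc2ccccc2n1C1CCN(CCCC(c2ccc(F)cc2)c2ccc(F)cc2)CC1` stands to compound 3 as compound 2 stands to compound 1, differing by hydroxymethyl in place of hydrogen on a saturated chain carbon bound to a sulfur, the same change at the same place. Since compound 3 already starts at a higher number than compound 1, and because the earlier step was an at least 4.4-fold higher number from compound 1 to compound 2 (0.64 log units; beyond the scatter), compound 4 is expected to move by a 5.0-fold higher number from compound 3 to compound 4 (0.70 log units; beyond the scatter) in this assay. For compound 4 the estimate in this assay is 12 mg/kg, expected to lie between 4 mg/kg and 40 mg/kg, most likely reported only as a limit.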

Compound 4, dose for half-maximal effect: > 3 mg/kg
Compound 4 ended at the assay's limit; the forecaster's own chance of this, stated with the estimate: 80%; the middle value does not contradict the limit.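

In this assay compound 4 gives no number, only the limit > 3 mg/kg, and that limit recurs in the series: the limit of > 3 mg/kg in this assay, at which 2 of the 4 values shown sit. Replacing methylsulfanyl with (2-hydroxyethyl)sulfanyl on the core of compound 3 therefore reads as an at least 1.2-fold higher number from compound 3 to compound 4 (0.09 log units; that floor lies within the scatter), which gives only a floor and fixes no size for the change on this core. Set beside each other, the two steps show that the result on one core does not settle the size of the change on the other: the same change on two cores in this assay, an at least 4.4-fold higher number (0.64 log units; beyond the scatter) from compound 1 to compound 2 and an at least 1.2-fold higher number (0.09 log units; that floor lies within the scatter) from compound 3 to compound 4; the limit leaves it open whether they differ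

The compounds shown leave open how far the true values of compound 2 and compound 4 lie past the limit, so the effect of the 2-hydroxyethyl group on either core remains unsized. They also leave open whether a different group on the sulfur, such as an ethyl or longer chain, an amine or a carboxylic acid, would give a readable number on these cores.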